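Swapping the aryl group on a weak cytotoxic core

A few compounds are considered here, and "the series" means these few. Any claim that something is new, unique, unknown or untested is made for them only; others in the source may bear on it.

Compound 1 `COc1cc(-c2cc(C(=O)Nc3nc4ccc(Cl)cc4s3)nc3cc(-c4ccccc4)nn23)cc(OC)c1OC` and compound 2 `Cc1cc2nc(NC(=O)c3cc(-c4ccc(F)cc4)n4nc(-c5ccccc5)cc4n3)sc2cc1C` share one core and were both tested in a functional assay on ACHN cells (Homo sapiens) for cytotoxicity, read by MTT assay, with a stated time of 48 h; a lower number here means a stronger inhibitor, a higher number a weaker inhibitor. Compound 1 gives 41700 nM there, and compound 2 gives 33000 nM, the two lying within the scatter of each other, so neither can be called the stronger. Compound 3 `COc1cc(-c2cc(C(=O)Nc3nc4cc(C)c(C)cc4s3)nc3cc(-c4ccccc4)nn23)cc(OC)c1OC` differs from compound 2 by 3,4,5-trimethoxyphenyl in place of 4-fluorophenyl on an aromatic carbon, the same aryl group that compound 1 carries. Within the data shown here, with no measured step of this kind, no change beyond the scatter is expected for a 1.2-fold higher number from compound 2 to compound 3 (0.06 log units; within the scatter). Compound 3 is therefore estimated at 38000 nM, between 15000 nM and 90000 nM.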

Compound 3, half-maximal inhibitory concentration: 3800 nM
Beside the measured number, compound 3's estimate is 10-fold (1.00 log units) above it, outside the stated range (below it).
By their numbers in this assay, from the lowest: compound 3; then compounds 2 and 1 (each within the scatter of the next).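

In this assay, the first single-place comparison shows that this aromatic carbon matters: 3,4,5-trimethoxyphenyl in place of 4-fluorophenyl gives an 8.7-fold lower number from compound 2 to compound 3 (0.94 log units; beyond the scatter). The amide-nitrogen substituent matters as well, since 5,6-dimethyl-1,3-benzothiazol-2-yl in place of 6-chloro-1,3-benzothiazol-2-yl gives an 11-fold lower number from compound 1 to compound 3 (1.04 log units; beyond the scatter). Nothing available accounts for either step.

The compounds shown leave open whether 4-methoxyphenyl or an amine on this aromatic carbon would give a similar number. They also leave open whether the aryl change would give a step of this size with 6-chloro-1,3-benzothiazol-2-yl on the amide nitrogen.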